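Quinazoline amines: swapping a small alcohol for a larger ether

The compounds below may be only part of what the source reports. "The series", "measured", "known", "first", "only" and "open" are said of these compounds alone.

Compound 1 `COc1cc2nc(N3CCC(OCC(C)(C)OC)CC3)nc(N)c2cc1OC`: 1.14 nM
Compound 2 `COc1cc2nc(N3CCC(OCC(C)(C)O)CC3)nc(N)c2cc1OC`: 1.28 nM

In an assay on brain for displacement of a labelled ligand from Adrenergic receptor alpha-1 (Rattus norvegicus) (on this read-out higher numbers stand for weaker inhibition and lower numbers for stronger inhibition), compound 2 gives 1.28 nM, the higher of the two numbers, with compound 1 within the scatter of it. Compound 3 `CCOC(C)(COC1CCN(c2nc(N)c3cc(OC)c(OC)cc3n2)CC1)c1ccccc1` carries 1-ethoxy-1-phenylethyl in place of 1-hydroxy-1-methylethyl on a saturated chain carbon bound to an oxygen on a saturated carbon. Going by the values given here, the single measured step, a 1.1-fold higher number from compound 1 to compound 2 (0.05 log units; within the scatter), touches only the oxygen on that chain and is within the scatter, so it bears on the new change only loosely. Among the compounds with values here, the larger group in compound 3 has no measured precedent here, and a modest change is expected, a 1.6-fold higher number from compound 2 to compound 3 (0.19 log units; within the scatter). Compound 3 is thus expected to give 2 nM in this assay, within 0.5 nM to 8 nM.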

Compound 3, inhibition constant: 0.15 nM
Beside the measured number, compound 3's estimate is 13-fold (1.12 log units) above it, and the stated range ends above it.
By their numbers in this assay, from the lowest: compound 3; then compounds 1 and 2 (each within the scatter of the next).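

Where the swap of methyl for hydrogen on the oxygen stayed within the scatter, replacing the whole group on this saturated chain carbon moves the number in this assay beyond it (an 8.5-fold lower number from compound 2 to compound 3 (0.93 log units; beyond the scatter); a 7.6-fold lower number from compound 1 to compound 3 (0.88 log units; beyond the scatter)). This position therefore responds to 1-ethoxy-1-phenylethyl, which brings a six-membered aromatic ring of carbon only. No measurement available here explains the gain.

From the compounds shown here alone, the phenyl ring and the ethoxy group enter together, so their separate shares remain open. Neither 1-hydroxy-1-phenylethyl nor an amine in place of the ethoxy group appears among these compounds.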